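The source may report more compounds than this note shows. Statements on the series, on what has been measured and on what is new or still open speak of the compounds shown alone.

Compound 1, `CC1(COc2ccc(F)cc2)Cn2cc([N+](=O)[O-])nc2O1`, gives > 64000 nM in an ADME assay on MRC5 cells (Homo sapiens) for cytotoxicity, read by fluorescence, with a stated time of 72 h (a lower number here means a stronger inhibitor, a higher number a weaker inhibitor), which is a limit of the assay rather than a number.
Compound 2, `CC1(COc2ccc(C(F)(F)F)cc2)Cn2cc([N+](=O)[O-])nc2O1`, gives > 64000 nM in this assay, again a limit.
Compound 3, `O=[N+]([O-])c1cn2c(n1)OC(COc1ccc(-c3ccc(F)cc3)nc1)C2`, gives > 64000 nM in this assay, also a limit.

From compound 1 to compound 2 the change is trifluoromethyl in place of fluoro on an aromatic carbon. Its step is a step that the two limits leave unreadable from compound 1 to compound 2, because both values sit at the limit of > 64000 nM in this assay, at which 3 of the 3 values shown sit. The cores of compound 1 and compound 3 differ, but that difference is not broken down here.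

Compound 4, `O=[N+]([O-])c1cn2c(n1)OC(COc1ccc(-c3ccc(C(F)(F)F)cc3)nc1)C2`, has not yet been measured in this assay. It arises from compound 3 by trifluoromethyl in place of fluoro on an aromatic carbon, the same change that was made from compound 1 to compound 2. Since compound 3 sits at the limit, compound 4 is expected to show a step that the limit leaves unreadable from compound 3 to compound 4, and its value in this assay is estimated at 80000 nM, most likely again a limit.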

Compound 4, half-maximal inhibitory concentration: > 64000 nM
Compound 4: only a limit was reported; the forecaster's own chance of this, stated with the estimate: 85%; the middle value is on the limit's open side.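

No step can be read from compound 3 to compound 4, because both values sit at a limit: the limit of > 64000 nM in this assay, at which 4 of the 4 values shown sit.

The compounds shown leave open what number any of them would give in this assay, and whether trifluoromethyl in place of fluoro changes it.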